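From isobutoxy to butoxy in the series

The source may hold more compounds than are shown below. What is called first, only, known or untested is meant among the compounds shown, and "the series" means these compounds.

In a functional assay on MCF7 cells (Homo sapiens) for antiproliferative activity, read by sulforhodamine B assay, with a stated time of 3 days (on this read-out higher numbers stand for an effect only at larger amounts of compound and lower numbers for an effect already at smaller amounts), compound 1 `CCCC1=C(OC)C(CCC)(CCC)C(=O)/C(=C(O)\C=C\c2ccccc2)C1=O` gives "not determined" (no result reported), so it offers no number for comparison. Compound 2 `CCCC1=C(OCCC(C)C)C(CCC)(CCC)C(=O)/C(=C(O)\C=C\c2ccccc2)C1=O` stands at 9.1 uM. Compound 3 `CCCC1=C(OCC(C)C)C(CCC)(CCC)C(=O)/C(=C(O)\C=C\c2ccccc2)C1=O` stands at 4.4 uM, the lower of the two numbers available.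

Compound 4 `CCCCOC1=C(CCC)C(=O)/C(=C(O)/C=C/c2ccccc2)C(=O)C1(CCC)CCC` differs from compound 3 by propyl in place of isopropyl on a saturated chain carbon bound to an oxygen on an unsaturated carbon, which reads as isobutoxy to butoxy. The two have the same atoms, joined differently.

For the measured compounds named here, only one measured step bears on this change: a 2.1-fold lower number from compound 2 to compound 3 (0.32 log units; beyond the scatter), modest and made at the same place. Going by the values given here, that step involves a different pair of groups, and no measured compound carries the butoxy group, so it serves only as a guide to size. The expected step is a 1.3-fold higher number from compound 3 to compound 4 (0.10 log units; within the scatter), with no clear change beyond the scatter anticipated in this assay. For compound 4 the estimated value is 5.5 uM, with an expected range of 2.5 uM to 12 uM.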

Compound 4, concentration for half-maximal effect: 5.3 uM
Compound 4: the middle estimate sits 1.0-fold (0.02 log units) above what was measured, within the range that was stated.
By their numbers in this assay, from the lowest: compounds 3, 4 and 2 (each within the scatter of the next, the first and the last beyond it).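

In this assay, isobutoxy to butoxy gives a 1.2-fold higher number from compound 3 to compound 4 (0.08 log units; within the scatter) and so, at this place on the shared core, moving the branch out of the chain leaves no change that can be told from the scatter. Hydrogen in place of methyl on a saturated chain carbon bound to two saturated chain carbons gives a 1.7-fold lower number from compound 2 to compound 4 (0.23 log units; within the scatter) and is also within the scatter, so compound 4 cannot be separated from either compound 2 or compound 3, although those two are separated from each other. No measurement at hand offers an explanation for these small steps.

From the compounds shown here alone, whether this flat response extends to a longer chain such as hexyloxy remains open. An ether chain ending in an amine or a carboxylic acid is equally untested among the compounds shown, so it is unknown whether either would move the number beyond the scatter.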